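This account rests on a few compounds, and the source may have more. Where it says the series, first, only, none or still open, it means among the compounds named here.

Measured compounds:
- compound 1, `CC(C)NS(=O)(=O)c1ccc2c(c1)C(n1ccccc1=O)=CC(C)(C)O2`: 676 nM
- compound 2, `CN(c1ccccc1)S(=O)(=O)c1ccc2c(c1)C(n1ccccc1=O)=CC(C)(C)O2`: 1.74 nM

In a functional assay with Rattus norvegicus as the target (on this read-out higher numbers stand for an effect only at larger amounts of compound and lower numbers for an effect already at smaller amounts), compound 2 gives the lowest of the two numbers; its nearest neighbour is compound 1, and the step of a 390-fold lower number from compound 1 to compound 2 (2.59 log units; beyond the scatter) separates them, a change that rests only on swapping isopropylamino for methyl(phenyl)amino on the sulfonyl sulfur. Compound 3, `CC1(C)C=C(n2ccccc2=O)c2cc(S(=O)(=O)NC(=O)Nc3ccccc3)ccc2O1`, has not yet been measured. It differs from compound 2 by (phenylcarbamoyl)amino in place of methyl(phenyl)amino on a sulfonyl sulfur. Among the compounds with values here, the only measured step that bears on this place is the one from compound 1 to compound 2, which was large, so a change at the group on the sulfonyl sulfur can move this assay strongly. Compound 3 keeps a phenyl ring but regains a hydrogen on the nitrogen attached to the sulfonyl sulfur, as in compound 1, so a sizable rise in the number is expected, a 110-fold higher number from compound 2 to compound 3 (2.06 log units; beyond the scatter). Compound 3 is therefore estimated at 200 nM, within the range 15 nM to 3000 nM.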

Compound 3, half-maximal effective concentration: 1410 nM
Estimate against measurement, compound 3: 7.1-fold (0.85 log units) below; low and high end bracket the measured number.
By their numbers in this assay, from the lowest: compound 2; then compound 1; then compound 3.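

In this assay, replacing methyl(phenyl)amino with (phenylcarbamoyl)amino on the sulfonyl sulfur gives an 810-fold higher number from compound 2 to compound 3 (2.91 log units; beyond the scatter), so a phenyl ring in this group does not by itself secure a low number. The result with phenylcarbamoyl in place of isopropyl on the sulfonamide nitrogen is a 2.1-fold higher number from compound 1 to compound 3 (0.32 log units; beyond the scatter), a modest step, and among these three compounds the low number appears only in compound 2, the one with no hydrogen on the nitrogen attached to the sulfonyl sulfur. No measurement shown here explains these differences.

The compounds shown do not separate the contribution of that hydrogen from those of the methyl group and the carbonyl. As far as these compounds go, how a dimethylamino group or a piperidine ring on the sulfonyl sulfur would read in this assay also remains open.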